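Benzoxazole series: reversing the ortho-aryl change at compound 2

A few compounds are considered here, and "the series" means these few. Any claim that something is new, unique, unknown or untested is made for them only; others in the source may bear on it.

Among the measured compounds shown here, in an assay on isolated protein for inhibition of ribosomal protein S6 kinase alpha-2 (Homo sapiens), with a stated time of 150 min (on this read-out lower numbers stand for stronger inhibition and higher numbers for weaker inhibition), compound 1 `COc1cc(Nc2nc3cccc(-c4c(F)cccc4OC)c3o2)cc(OC)c1OC` gives 20 nM, and compound 2 `COc1cc(Nc2nc3cccc(-c4ccccc4OC(F)(F)F)c3o2)cc(OC)c1OC` gives 4000 nM, which is the highest of the two numbers recorded; the only step, a 200-fold higher number from compound 1 to compound 2 (2.30 log units; beyond the scatter), ran against compound 2. For the measured compounds named here, compound 3 `CCOc1cccc(F)c1-c1cccc2nc(Nc3cc(OC)c(OC)c(OC)c3)oc12` carries 2-ethoxy-6-fluorophenyl in place of 2-(trifluoromethoxy)phenyl on an aromatic carbon, a group that resembles the one in compound 1 rather than compound 2, so that step is the one bearing on it. A large drop in this assay is therefore expected, a 100-fold lower number from compound 2 to compound 3 (2.00 log units; beyond the scatter), though not necessarily all the way back. Compound 3 is estimated at 40 nM, between 10 nM and 250 nM.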

Compound 3, half-maximal inhibitory concentration: 490 nM
Compound 3: the middle estimate sits 12-fold (1.09 log units) below what was measured; the whole stated range lies below it.
By their numbers in this assay, from the lowest: compound 1; then compound 3; then compound 2.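

In this assay the 2-ethoxy-6-fluorophenyl group recovers only part of the loss seen with 2-(trifluoromethoxy)phenyl, with an 8.2-fold lower number from compound 2 to compound 3 (0.91 log units; beyond the scatter) as the step. Methyl in place of hydrogen on the saturated chain carbon bound to the oxygen still gives a 25-fold higher number from compound 1 to compound 3 (1.39 log units; beyond the scatter) as the step, so with the fluorine held in place, this position separates methoxy from ethoxy sharply.

Going by these compounds, the contribution of the fluorine on its own remains open, as does the reading of a propoxy chain or a hydroxyl group here. No measured evidence accounts for the size of either step.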